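Carbamoyl in place of carboxy on the shared core

A few compounds are considered here, and "the series" means these few. Any claim that something is new, unique, unknown or untested is made for them only; others in the source may bear on it.

Compound 1 `CCn1nc(C)cc1C(=O)Nc1nc2cc(C(N)=O)cc(OC)c2n1CCCNC(=O)CCc1cccnc1` carries the carbamoyl group on the shared core, with a pyridinyl propanamide on the chain. In an assay for activation of interferon regulatory factor 3 (Homo sapiens), read by a luciferase reporter, with a stated time of 20 h (a lower number here means that less compound is needed, a higher number that more compound is needed for the effect), compound 1 gives > 100000 nM, which is a limit of the assay and not a number. Compound 2 `CCn1nc(C)cc1C(=O)Nc1nc2cc(C(=O)OC)cnc2n1CCCNC(=O)OC(C)(C)C` bears the methyl ester and a tert-butyl carbamate on the chain. In this assay compound 2 gives > 100000 nM, again only a limit. Compound 3 `CCn1nc(C)cc1C(=O)Nc1nc2cc(C(=O)O)cnc2n1CCCNC(=O)OC(C)(C)C` is the free acid. In this assay compound 3 gives > 100000 nM, also a limit. The step that the two limits leave unreadable from compound 2 to compound 3 cannot be sized because of the limit of > 100000 nM in this assay, at which 3 of the 3 values shown sit. Compound 3 thus stands nowhere distinct; every value in the set sits at the same limit.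

Compound 4 `CCn1nc(C)cc1C(=O)Nc1nc2cc(C(N)=O)cnc2n1CCCNC(=O)OC(C)(C)C` differs from compound 3 by amino in place of hydroxy on a carbonyl carbon, the same change read one bond further out as carboxy to carbamoyl. For the measured compounds named here, the only measured step, a step that the two limits leave unreadable from compound 2 to compound 3, bears on the ester and acid and yields no readable size. Compound 1 already holds the carbamoyl group, and its result > 100000 nM is a limit. No step beyond the scatter is expected in this assay. Compound 4 is estimated at 200000 nM, with a range from 50000 nM to 1000000 nM, most likely reported again as a limit. The estimate implies a step that the limit leaves unreadable from compound 3 to compound 4, which is expected to be no change beyond the scatter.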

Compound 4, half-maximal effective concentration: > 100000 nM
Compound 4 gave a limit, no number (the forecaster's own chance of this, stated with the estimate: 85%); the middle value does not contradict the limit.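

In this assay compound 4 gives > 100000 nM as a limit and not a number. For the compounds shown here, no step from compound 2 or compound 3 to compound 4 can be read, because of this shared limit: the limit of > 100000 nM in this assay, at which 4 of the 4 values shown sit.

The compounds shown leave open whether carboxy to carbamoyl on this core changes the response at all, since none gives a readable value.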